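Lengthening the chain: from compound 3 to compound 4

A few compounds are considered here, and "the series" means these few. Any claim that something is new, unique, unknown or untested is made for them only; others in the source may bear on it.

Measured compounds:
- compound 1, `CC(C)(C)NC(=O)Oc1ccc(C2=NCCS2)cc1`: "not active" (no number reported)
- compound 2, `O=C(NC1CCCCC1)Oc1ccc(-c2csnn2)cc1`: 28%
- compound 3, `CCCCCCNC(=O)Oc1ccccc1`: 41%

Of the compounds shown here, three have been tested in an assay on cell membranes (strain Wistar) for inhibition of Monoglyceride lipase (Rattus norvegicus), read by HPLC, tested at 100 uM; on this read-out higher numbers stand for more inhibition at the one concentration tested (going by the name of the read-out) and lower numbers for less inhibition. Compound 1 gives "not active" (no number reported), so no number is reported for it. Compound 2 gives 28% and compound 3 gives 41%. Compound 3 stands highest of the two numbers; its nearest neighbour is compound 2, which lies beyond the usual scatter below it. The three compounds differ in more than one place, so none of these gaps can be tied to a single change.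

The next compound, compound 4, is `CCCCCCCCCCCCNC(=O)Oc1ccccc1`. It differs from compound 3 in one place: hexyl in place of hydrogen on a saturated chain carbon, six bonds along the chain from an amide-type nitrogen. Among the measured compounds shown here, no measured pair isolates such a change, so there is nothing to lean on. A moderate rise is expected, and the step of a number 11 percentage points higher from compound 3 to compound 4 (beyond the scatter) is the estimate. Compound 4 is expected to give 52%, within a range from 28% to 76%.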

Compound 4, a percentage reported as inhibition, at one concentration (the size of the read-out at that concentration, not a potency): 36%
Estimate against measurement, compound 4: 16 percentage points above; low and high end bracket the measured number.
By their numbers in this assay, from the lowest: compounds 2, 4 and 3 (each within the scatter of the next, the first and the last beyond it).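

In this assay, putting hexyl in place of hydrogen on a saturated chain carbon, six bonds along the chain from an amide-type nitrogen, gives a number 5 percentage points lower from compound 3 to compound 4 (within the scatter). Among the compounds shown here, this is the first pair of compounds here that differ in one place, and it shows that this substantial addition to the chain leaves the read-out within the normal spread of repeat measurements, so no effect of the added carbons can be claimed at the one concentration tested. Nothing available explains why the result turned out this way.

Still open, as far as these compounds go, is whether a chain of intermediate length, such as octyl, or a longer chain would separate from these two compounds. An amine or a carboxylic acid in place of hydrogen at this same carbon also remains an open case.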